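A few compounds are considered here, and "the series" means these few. Any claim that something is new, unique, unknown or untested is made for them only; others in the source may bear on it.

In a functional assay on ileum (Cavia porcellus) for antagonist activity, with a stated time of 30 s (a higher number here means a weaker inhibitor, a lower number a stronger inhibitor), compound 1 `O=C(O)c1cc(=O)c2ccc(OCCCCCOc3ccccc3)cc2o1` gives 0.4 ug/mL, compound 2 `O=C(O)c1cc(=O)c2ccc(OCCCCCCCOc3ccccc3)cc2o1` gives 1.8 ug/mL and compound 3 `O=C(O)c1cc(=O)c2ccc(OCCCCCOc3cccc(O)c3)cc2o1` gives 1.5 ug/mL. Compound 3 lies within the scatter of compound 2, and its number is higher than that of compound 1. Compound 4 `O=C(O)c1cc(=O)c2ccc(OCCCCCOc3cccc(OCc4ccccc4)c3)cc2o1` differs from compound 3 by one change, (benzyl in place of hydrogen on an oxygen on an aromatic ring), with benzyl in place of hydrogen on an oxygen on an aromatic ring. The closest evidence is a 3.8-fold higher number from compound 1 to compound 3 (0.57 log units; beyond the scatter), where hydroxy replaces hydrogen on an aromatic carbon. The other modest step, a 4.5-fold higher number from compound 1 to compound 2 (0.65 log units; beyond the scatter), lies in the chain. Neither step tests benzyl on that oxygen, so no clear direction can be expected. The expected change is a 1.2-fold lower number from compound 3 to compound 4 (0.06 log units; within the scatter), which would stay within the scatter. For compound 4 the estimated value is 1.3 ug/mL, with an expected range of 0.4 ug/mL to 5 ug/mL.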

Compound 4, half-maximal inhibitory concentration: 1 ug/mL
Compound 4: the middle estimate sits 1.3-fold (0.11 log units) above what was measured; measured number inside the range.
By their numbers in this assay, from the lowest: compound 1; then compounds 4, 3 and 2 (each within the scatter of the next).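

Putting benzyl on the oxygen of compound 3, a group of seven carbons with one aromatic ring, gives a 1.5-fold lower number from compound 3 to compound 4 (0.18 log units; within the scatter), so this position accepts that large change without a step beyond the scatter. Benzyloxy in place of hydrogen on the aromatic carbon still leaves a 2.5-fold higher number from compound 1 to compound 4 (0.40 log units; beyond the scatter), so compounds 3 and 4 both stand above compound 1 on this aromatic carbon. Nothing available accounts for either step. From the compounds shown here alone, whether methoxy or an amine at this place would come closer to compound 1 remains open, as does how benzyloxy behaves on the longer chain of compound 2.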